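The compounds below may be only part of what the source reports. "The series", "measured", "known", "first", "only" and "open" are said of these compounds alone.

Measured compounds so far:
compound 1, `CC1(C)C2CCC1(C)C(OC(=O)/C=C/c1ccc(O)c(O)c1[N+](=O)[O-])C2` — "not determined" (no result reported) in a functional assay on SGC-7901 cells (Homo sapiens) for inhibition, read by MTT assay; a lower number here means a stronger inhibitor, a higher number a weaker inhibitor
compound 2, `CC1(C)C2CCC1(C)C(OC(=O)/C=C/c1ccc(O)c(O)c1)C2` — 12000 nM
compound 3, `O=C(/C=C/c1cc(O)c(O)c([N+](=O)[O-])c1)OCCc1ccccc1` — "not determined" (no result reported)

Compound 3 thus stands without a single number in this assay; it is one of two entries in the set that carry no result, the other being compound 1. Within the data shown here, the only numbered point is compound 2, which in this assay gives 12000 nM. Compound 4, `O=C(/C=C/c1cc(O)c(O)c(Cl)c1)OCCc1ccccc1`, differs from compound 3 as follows: chloro in place of nitro on an aromatic carbon. Among the measured compounds shown here, no step between measured compounds exists, so nothing here tells how large a shift in this assay such a change produces; the expected step is of unknown size and direction. Resting only on the figure of compound 2, compound 4 is estimated at 10000 nM, with a range from 3000 nM to 40000 nM.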

Compound 4, half-maximal inhibitory concentration: 8180 nM
For compound 4 the middle estimate is 1.2-fold (0.09 log units) above the measured one; low and high end bracket the measured number.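

Among these compounds, compound 3 carries no single number to set against compound 4, so no step between the two can be read. As far as these compounds go, what chloro in place of nitro does to this inhibition stays open, and no evidence bears on the result of compound 4.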